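The compounds below may be only part of what the source reports. "The series", "measured", "known", "first", "only" and "open" are said of these compounds alone.

Measured compounds:
compound 1, `NC(=S)N/N=C/c1ccc2ccccc2n1`: > 100000 nM
compound 2, `CN(C)C(=S)N/N=C/c1cnc2ccccc2n1`: 90 nM

In a functional assay on HL-60 cells (Homo sapiens) for antiproliferative activity, read by sulforhodamine B assay, with a stated time of 72 h (on this read-out lower numbers stand for stronger inhibition and higher numbers for weaker inhibition), compound 1 gives > 100000 nM, which is a limit of the assay and not a number. Compound 1 therefore stands at the limit of > 100000 nM in this assay, at which 1 of the 2 values shown sits, and its true value is not known. Compound 2, built on a different core and bearing two methyl groups, gives 90 nM in this assay. For the measured compounds named here, no single step connects compound 2 to compound 1, so the two values show only that one compound is read as a number and the other as a limit.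

Compound 3, `COc1ccc(NC(=S)N/N=C/c2ccc3ccccc3n2)cc1`, has not yet been measured in this assay. It differs from compound 1 by 4-methoxyphenyl in place of hydrogen on an amide-type nitrogen. Because compound 1 sits at the limit of > 100000 nM in this assay, at which 1 of the 2 values shown sits, the size of the step can be set only loosely, but a move away from the limit toward a measurable number, that is toward stronger inhibition, is expected. Compound 3 is expected to give about 2000 nM, between 200 nM and 50000 nM. The step from compound 1 to compound 3 that this estimate means is expected to be an at least 50-fold lower number from compound 1 to compound 3 (1.69 log units; beyond the scatter).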

Compound 3, half-maximal inhibitory concentration: 43800 nM
Beside the measured number, compound 3's estimate is 22-fold (1.34 log units) below it; low and high end bracket the measured number.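

Setting 4-methoxyphenyl in place of hydrogen on an amide-type nitrogen, the one bound to the thiocarbonyl carbon, gives an at least 2.2-fold lower number from compound 1 to compound 3 (0.35 log units; beyond the scatter) in this assay, so a substituent at this position can bring the core of compound 1 into the range where a number can be read. In this assay compound 1 gives > 100000 nM, which is a limit of the assay and not a number. The step therefore sets only a lower bound on the effect of this change, and its full size remains unknown: the limit of > 100000 nM in this assay, at which 1 of the 3 values shown sits.

The compounds shown do not tell whether the step comes from the aromatic ring itself or from its methoxy group, a question that a plain phenyl or a 4-carboxyphenyl on the same nitrogen would address. Compound 1 and compound 3 differ from compound 2 in more than one place, so for compound 2 they leave open how much of its separate value of 90 nM belongs to its core and how much to its two methyl groups.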